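This account rests on a few compounds, and the source may have more. Where it says the series, first, only, none or still open, it means among the compounds named here.

Compound 1 `O=C(O)c1ccc(CN2C(=O)S/C(=C\c3cccnc3)C2=O)cc1` was tested in a functional assay on MCF7 cells (Homo sapiens) for cytotoxicity, read by MTT assay, with a stated time of 24 h (on this read-out higher numbers stand for weaker inhibition and lower numbers for stronger inhibition), where compound 1 gives 100000 nM. Going by the values given here, only one other compound has been measured: compound 2 `O=C(O)c1ccc(CN2C(=O)S/C(=C\c3ccncc3)C2=O)cc1`, which in this assay gives 84000 nM, so the two numbers sit within the usual scatter of each other, as the step of a 1.2-fold lower number from compound 1 to compound 2 (0.08 log units; within the scatter) shows. Compound 3 `O=C(O)c1ccc(CN2C(=O)S/C(=C\c3cccs3)C2=O)cc1` differs from compound 1 in one place: thiophen-2-yl in place of pyridin-3-yl on a double-bonded chain carbon bound to a double-bonded ring carbon. Among the compounds with values here, the single measured step swapped one pyridyl ring for another at that same place and showed nothing beyond the scatter, so it bears on the thiophen-2-yl change only loosely. No step beyond the scatter is therefore expected in this assay. Compound 3 is estimated at 100000 nM, within a range of 40000 nM to 250000 nM, which means an expected step of no change at the digits printed from compound 1 to compound 3 (within the scatter).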

Compound 3, half-maximal inhibitory concentration: 76000 nM
Estimate against measurement, compound 3: 1.3-fold (0.12 log units) above, and the stated range covers the measured number.
By their numbers in this assay, from the lowest: compounds 3, 2 and 1 (each within the scatter of the next).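

Replacing a six-membered aromatic ring with a five-membered one, with sulfur as its hetero atom instead of nitrogen, gives a 1.3-fold lower number from compound 1 to compound 3 (0.12 log units; within the scatter) and a 1.1-fold lower number from compound 2 to compound 3 (0.04 log units; within the scatter) on a double-bonded chain carbon bound to a double-bonded ring carbon. So in this assay, a change in ring size and hetero atom at this place, and not only a pyridyl swap, leaves the numbers within the scatter. Nothing available explains this result.

On these data alone, it remains open whether any group at this place can produce a step beyond the scatter. A phenyl ring carrying an amine would be one such test.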